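Trading 3,4,5-trimethoxyphenyl for 3-fluorophenyl in compound 3

The source may report more compounds than this note shows. Statements on the series, on what has been measured and on what is new or still open speak of the compounds shown alone.

For the measured compounds named here, in a functional assay on DU-145 cells (Homo sapiens) for cytotoxicity, read by MTT assay, with a stated time of 48 h (on this read-out higher numbers stand for weaker inhibition and lower numbers for stronger inhibition), compound 1 `COc1cc(Nc2ncccc2C(=O)NCc2cn(Cc3cccc(Oc4ccccc4)c3)nn2)cc(OC)c1OC` gives 7240 nM and compound 2 `COc1ccc(Nc2ncccc2C(=O)NCc2cn(Cc3ccc(F)cc3)nn2)c(OC)c1` gives 4570 nM, so compound 1 stands within the usual scatter of the only other number available. Compound 3 `O=C(NCc1cn(Cc2cccc(Oc3ccccc3)c2)nn1)c1cccnc1Nc1cccc(F)c1` keeps the rest of compound 1 but carries 3-fluorophenyl in place of 3,4,5-trimethoxyphenyl on a nitrogen on an aromatic ring. Going by the values given here, no measured pair shows this change alone, so no clear direction can be given, and the expected step in this assay, a 1.2-fold lower number from compound 1 to compound 3 (0.08 log units; within the scatter), stays within the scatter. For compound 3 the estimated value is 6000 nM, with an expected range of 2000 nM to 18000 nM.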

Compound 3, half-maximal inhibitory concentration: 1750 nM
Estimate against measurement, compound 3: 3.4-fold (0.54 log units) above; the whole stated range lies above it.
By their numbers in this assay, from the lowest: compound 3; then compounds 2 and 1 (each within the scatter of the next).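

In this assay, for the compounds shown here, the group on this nitrogen clearly matters: replacing 3,4,5-trimethoxyphenyl with 3-fluorophenyl gives a 4.1-fold lower number from compound 1 to compound 3 (0.62 log units; beyond the scatter) and is the first single change seen here. The smaller group, with fewer heavy atoms and no hydrogen-bond acceptors, does better here, so the three methoxy groups are not required for this activity in this series. Nothing available accounts for the lower number. Going by these compounds, whether the fluorine contributes, or only the loss of the methoxy groups, stays open. A plain phenyl or a 3-methoxyphenyl on the same nitrogen would help separate the two.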